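The source may report more compounds than this note shows. Statements on the series, on what has been measured and on what is new or still open speak of the compounds shown alone.

Values from a physicochemical assay for pharmacokinetics, at pH 6 (on this read-out lower numbers stand for a shorter-lived compound and higher numbers for a longer-lived compound), for the series so far

compound 1 `O=C(Sc1cccnc1C(=O)O)c1ccc(Cl)cc1` gives 7.9 h
compound 2 `O=C(Sc1cccnc1C(=O)O)c1cccc(C(F)(F)F)c1` gives 3.9 h
compound 3 `COc1cccc(C(=O)Sc2cccnc2C(=O)O)c1` gives 11.9 h

Compound 1 at 7.9 h lies within the scatter of compound 3 at 11.9 h and so cannot be told apart from it. Compound 2 has the lowest number of the three at 3.9 h and stands beyond the scatter from both.

Compound 4 `O=C(Sc1cccnc1C(=O)O)c1ccc(F)cc1` is not yet measured. It differs from compound 1 in one place (fluoro in place of chloro on an aromatic carbon) with fluoro in place of chloro on an aromatic carbon, para to a large group.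

Among the compounds with values here, the only measured single-place change is a 3.1-fold higher number from compound 2 to compound 3 (0.48 log units; beyond the scatter) for methoxy in place of trifluoromethyl, a modest step. It involves neither chloro nor fluoro, so it bears only loosely and gives no direction here. No step beyond the scatter is therefore expected, with compound 1 at 7.9 h as the anchor.

The expected step is a 1.3-fold higher number from compound 1 to compound 4 (0.10 log units; within the scatter) in this estimate. Compound 4 is estimated at 10 h with 6 h to 16 h as the expected range.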

Compound 4, half-life: 12.1 h
The estimate for compound 4 lay 1.2-fold (0.08 log units) below the measured number; measured number inside the range.
By their numbers in this assay, from the lowest: compound 2; then compounds 1, 3 and 4 (each within the scatter of the next).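

In this assay, within the data shown here, fluoro in place of chloro on an aromatic carbon, para to a large group, gives a 1.5-fold higher number from compound 1 to compound 4 (0.19 log units; within the scatter) and so cannot be told from no step at all. Among these compounds, this is the first single-place reading at this position, and it shows that the read-out does not separate these two halogens there. Among the compounds shown here, the only earlier step, a 3.1-fold higher number from compound 2 to compound 3 (0.48 log units; beyond the scatter) for methoxy in place of trifluoromethyl, involves neither halogen, and no supporting data bear on why chloro and fluoro read alike here.

Open, going by these compounds, is whether this position stays as undemanding with a group other than a halogen, such as an amine, a nitrile or a longer chain. Also open, on these data alone, is whether bromo, the next halogen, would stay within the scatter of compound 1 and compound 4.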